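The compounds below may be only part of what the source reports. "The series", "measured", "known", "first", "only" and "open" are said of these compounds alone.

In this study two compounds have numbers: compound 2 `CCC/C=C/C(=O)Nc1cccc(Oc2nc(Nc3cccc(OC)c3)nc3ccsc23)c1` gives 5020 nM in a functional assay on MCF7 cells (Homo sapiens) for inhibition, read by MTT assay, with a stated time of 72 h; a higher number here means a weaker inhibitor, a lower number a stronger inhibitor; compound 1 `COc1cccc(Nc2nc(Oc3cccc(NC(=O)C=C(C)C)c3)c3sccc3n2)c1` gives 35800 nM.

Compound 2 stands lowest of the two numbers, and its nearest neighbour is compound 1. For the measured compounds named here, the one measured step, a 7.1-fold lower number from compound 1 to compound 2 (0.85 log units; beyond the scatter), changes only the acyl group, pent-1-en-1-yl in place of 2-methylprop-1-en-1-yl on a carbonyl carbon.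

Compound 3 `CCC/C=C/C(=O)Nc1cccc(Oc2nc(Nc3cccc(C#N)c3)nc3ccsc23)c1` is yet to be measured. It differs from compound 2 by cyano in place of methoxy on an aromatic carbon, meta to a large group. No measured step touches this part of the molecule, so the step between compound 1 and compound 2 does not bear on it, and the change has no precedent among these compounds. The expectation is therefore a step of a 1.0-fold lower number from compound 2 to compound 3 (0.00 log units; within the scatter), within the scatter. Compound 3 is estimated at 5000 nM, with a range from 1500 nM to 16000 nM.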

Compound 3, half-maximal inhibitory concentration: 49100 nM
The estimate for compound 3 lay 9.8-fold (0.99 log units) below the measured number, outside the stated range (above it).
By their numbers in this assay, from the lowest: compound 2; then compounds 1 and 3 (each within the scatter of the next).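

In this assay, exchanging methoxy for cyano on the (3-methoxyphenyl)amino part gives a 9.8-fold higher number from compound 2 to compound 3 (0.99 log units; beyond the scatter), a step beyond the scatter. This shows that the position is not silent, and that the acyl group, the only part changed in the earlier step, is not the only part of the molecule that moves the number. No measurement available here bears on why this exchange raises the number.

From the compounds shown here alone, it remains open where other groups at this carbon, such as an amine, a hydroxyl or a chlorine, would fall relative to methoxy and cyano. Also open, going by these compounds, is whether the same exchange would give a step of similar size with the 2-methylprop-1-en-1-yl acyl group of compound 1.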